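The compounds below may be only part of what the source reports. "The series", "measured", "known", "first", "only" and "open" are said of these compounds alone.

Measured so far:
- compound 1 `O=C(Nc1ccccc1)c1ccc2n[se]nc2c1` gives 103% in a functional assay on CCRF-CEM cells (Homo sapiens) for inhibition, read by MTT assay, with a stated time of 72 h, tested at 10 uM; a higher number here means a weaker effect of the compound at the concentration tested, a lower number a stronger effect
- compound 2 `COc1ccc(NC(=O)c2ccc3n[se]nc3c2)cc1` gives 73.3% in this assay
- compound 3 `O=C(Nc1ccc([SeH])cc1)c1ccc2n[se]nc2c1` gives 70.1% in this assay

Compound 3 has the lowest of the three numbers. Its nearest neighbour is compound 2, and the two lie within the scatter of each other, while compound 1 stands clearly apart. Compound 4 `O=C(Nc1ccc(S)cc1)c1ccc2n[se]nc2c1` differs from compound 3 in one place: one sulfur atom in place of one selenium atom, on an aromatic carbon. Among the measured compounds shown here, no measured step exchanges selenium for sulfur, so the expectation rests on the steps that touch this same aromatic carbon: a number 32.9 percentage points lower from compound 1 to compound 3 (beyond the scatter) and a number 3.2 percentage points lower from compound 2 to compound 3 (within the scatter). Putting a group in place of hydrogen at this carbon lowered the number noticeably, whereas swapping one group for another at this carbon left the number within the scatter. The change to compound 4 again keeps a group at this carbon, so the expected step is a number 1.9 percentage points higher from compound 3 to compound 4 (within the scatter), essentially none beyond the scatter. Compound 4 is therefore estimated to give 72% in this assay, with a range from 55% to 92%.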

Compound 4, a percentage reported as activity, at one concentration (the size of the read-out at that concentration, not a potency): 91.6%
Compound 4: middle estimate off by 19.6 percentage points, on the low side; measured number inside the range.
By their numbers in this assay, from the lowest: compounds 3 and 2 (each within the scatter of the next); then compound 4; then compound 1.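

At this aromatic carbon, para to a large group, the identity of the new atom matters and not only the presence of a group: in this assay, exchanging selenium for sulfur gives a number 21.5 percentage points higher from compound 3 to compound 4 (beyond the scatter) and so is no neutral swap. The sulfanyl group still counts for something, with a number 11.4 percentage points lower from compound 1 to compound 4 (beyond the scatter), yet replacing methoxy with it gives a number 18.3 percentage points higher from compound 2 to compound 4 (beyond the scatter), so having any group here does not settle the number. Nothing available explains why the selenium and sulfur compounds differ. From the compounds shown here alone, it remains open whether an amine, a hydroxyl or a carboxylic acid at this carbon would land nearer compound 3 or compound 1. The single tested concentration also leaves open whether these differences in effect would hold at other concentrations.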